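Moving the trifluoromethyl group around a pyridine ring

The source may hold more compounds than are shown below. What is called first, only, known or untested is meant among the compounds shown, and "the series" means these compounds.

Three compounds share a spiro-fused amide core and were tested in a functional assay on CHO cells for antagonist activity at Orexin/Hypocretin receptor type 1 (Homo sapiens), read by FLIPR and calcium flux; a higher number here means a more potent compound, by a factor of ten per unit of this negative logarithm, a lower number a less potent compound. Compound 1 `Cc1ccc(-c2ncccn2)c(C(=O)N2CCC3(CC3)C[C@H]2CNc2ccc(Cl)cn2)c1` gives 7.6. Compound 2 `Cc1ccnc(NC[C@@H]2CC3(CC3)CN2C(=O)c2nc(C)sc2-c2ccccc2)n1` gives 6.1. Compound 3 `O=C(c1cc(Cl)ccc1-c1ncccn1)N1CC2(CC2)C[C@H]1CNc1cc(C(F)(F)F)ccn1` gives 8.1, the highest of the three numbers; its gap to compound 1 and its much larger gap to compound 2 both lie beyond the scatter of repeated measurements, so compound 3 is the most potent of the measured set.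

Compound 4 `O=C(c1cc(Cl)ccc1-c1ncccn1)N1CC2(CC2)C[C@H]1CNc1ccc(C(F)(F)F)cn1` is the next step. It has the same atoms as compound 3, joined differently: 5-(trifluoromethyl)pyridin-2-yl in place of 4-(trifluoromethyl)pyridin-2-yl on an amine nitrogen. Within the data shown here, no measured pair in this set isolates such a change, so there is no direct precedent to lean on. The expectation is that compound 4 stays close to compound 3, with a step of a number 0.10 log units lower from compound 3 to compound 4 (within the scatter) that is likely within the scatter. In this assay compound 4 is therefore estimated at 8, with a plausible range from 7.3 to 8.7.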

Compound 4, negative logarithm of the antagonist equilibrium constant: 8.1
Beside the measured number, compound 4's estimate is 0.10 log units below it; low and high end bracket the measured number.
By their numbers in this assay, from the lowest: compound 2; then compound 1; then compounds 3 and 4 (each within the scatter of the next).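

Moving the trifluoromethyl group, with 5-(trifluoromethyl)pyridin-2-yl in place of 4-(trifluoromethyl)pyridin-2-yl on the amine nitrogen, gives no change at the digits printed from compound 3 to compound 4 (within the scatter) in this assay. This is the first pair shown that differs in one place only, and it shows that, on this core, the two placements of the trifluoromethyl group cannot be told apart by this read-out. Nothing in the data shown explains why the two placements read alike.

As far as these compounds go, whether the same holds for other groups remains open: a nitrile or a methoxy group in these two placements might or might not read alike. Also open, from the compounds shown here alone, is whether the two placements would still match with the shared core's other parts changed, since a single pair cannot show how general this result is.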